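A few compounds are considered here, and "the series" means these few. Any claim that something is new, unique, unknown or untested is made for them only; others in the source may bear on it.

Measured so far:
Compound 1, `Cc1ccc(S(=O)(=O)Oc2ccc3c(c2)C(=O)C=CC3=O)cc1`: 15100 nM
Compound 2, `COc1ccc2c(c1)C(=O)C=CC2=O`: 22700 nM

Both compounds share the same core and were tested in a functional assay on HeLa cells (Homo sapiens) for cytotoxicity; on this read-out lower numbers stand for stronger inhibition and higher numbers for weaker inhibition. Compound 1 gives 15100 nM, and compound 2 gives 22700 nM. These two numbers lie within the usual scatter of repeated measurements of each other, so nothing can be said about which of the two is the more potent; compound 2 simply has a number of the same general size as compound 1. For the measured compounds named here, the two compounds also differ from each other in more than one place, so no single structural step connects them.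

Compound 3, `C=CCOc1ccc2c(c1)C(=O)C=CC2=O`, has not yet been measured. It differs from compound 2 in one place only: vinyl in place of hydrogen on a saturated chain carbon bound to an oxygen on an aromatic ring. This is a small addition on the outer end of the side group and leaves the core untouched. Going by the values given here, with no comparable step among the measured compounds to draw on, the expectation is that the number in this assay for compound 3 will stay close to that of compound 2, with any step from compound 2 to compound 3 expected to be a 1.3-fold lower number from compound 2 to compound 3 (0.10 log units; within the scatter), not beyond the scatter. Compound 3 is therefore estimated at 18000 nM, with a range from 8000 nM to 45000 nM.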

Compound 3, half-maximal inhibitory concentration: 27200 nM
Beside the measured number, compound 3's estimate is 1.5-fold (0.18 log units) below it; the range from low to high includes it.
By their numbers in this assay, from the lowest: compounds 1, 2 and 3 (each within the scatter of the next).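

In this assay, for the compounds shown here, the swap of methoxy for allyloxy is the only comparison here between compounds that differ in one place, and it reads as a 1.2-fold higher number from compound 2 to compound 3 (0.08 log units; within the scatter) and so leaves compound 2 and compound 3 indistinguishable. This shows that, on a saturated chain carbon bound to an oxygen on an aromatic ring, vinyl in place of hydrogen adds two carbon atoms without a measurable difference in the number, which the earlier pair of compounds could not show because they differ in more than one place. No measured evidence is available to explain this result.

This single step describes one group at one place, so it gives no trend, and it cannot say how far the side group can be extended or altered before the number moves beyond the scatter. As far as these compounds go, whether a longer chain, an amine or a carboxylic acid at the end of the side group would give a number close to those of compound 2 and compound 3, or a clearly different one, remains open.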